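Enantiomer of the benzyl carbamate in the series

This account rests on a few compounds, and the source may have more. Where it says the series, first, only, none or still open, it means among the compounds named here.

Among the compounds with values here, compound 2 `COc1cc2nc(N3CCN(C(=O)OCc4ccccc4)[C@@H]4CCCC[C@@H]43)nc(N)c2cc1OC` gives the lowest number so far in an assay on CHO cells for displacement of a labelled ligand from Alpha-1D adrenergic receptor (Homo sapiens), with a stated time of 30 min (a lower number here means a stronger inhibitor, a higher number a weaker inhibitor), at 0.0398 nM. Within the data shown here, the only other measured member, compound 1 `COc1cc2nc(N3CCN(C(C)=O)[C@H]4CCCC[C@H]43)nc(N)c2cc1OC`, gives 105 nM in this assay, a number well beyond the scatter away from compound 2; no single-point step connects these two, so the pair only shows the spread of the series.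

Compound 3 `COc1cc2nc(N3CCN(C(=O)OCc4ccccc4)[C@H]4CCCC[C@H]43)nc(N)c2cc1OC` is related to compound 2 as follows: the two compounds have the same atoms and bonds and differ only in configuration as drawn: 2 of 2 stereo elements differ (all stereocentres are inverted: mirror images); a stereocentre at a saturated ring carbon is drawn R in compound 2 and S in compound 3; a stereocentre at a saturated ring carbon is drawn S in compound 2 and R in compound 3. Nothing leaves and nothing enters; the two compounds are mirror images.

Among the measured compounds shown here, no measured step of this kind exists, so the expectation rests on compound 2 alone. Inversion of both stereocentres is expected to weaken binding in this assay by a step of a 75-fold higher number from compound 2 to compound 3 (1.88 log units; beyond the scatter), with a wide margin in either direction. Compound 3 is accordingly estimated at 3 nM, within a range of 0.1 nM to 100 nM.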

Compound 3, inhibition constant: 3.98 nM
For compound 3 the middle estimate is 1.3-fold (0.12 log units) below the measured one; low and high end bracket the measured number.
By their numbers in this assay, from the lowest: compound 2; then compound 3; then compound 1.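

In this assay the number depends strongly on the drawn configuration of the two saturated ring carbons: inverting both gives a 100-fold higher number from compound 2 to compound 3 (2.00 log units; beyond the scatter). That step can be put down to configuration alone, because of: the fact that compounds 2 and 3 differ only in the configuration as drawn. Within a single configuration, benzyloxy in place of methyl on a carbonyl carbon gives a 26-fold lower number from compound 1 to compound 3 (1.42 log units; beyond the scatter), so the effect of this group on the number can now be read directly, which the earlier pair of compounds did not allow.

From the compounds shown here alone, it remains open whether inversion shifts the number to a similar extent when methyl sits on the carbonyl carbon, and so whether the two changes combine additively. Going by these compounds, it is also open how a tert-butoxy group or a longer chain such as phenylpropyloxy would compare with benzyloxy at this carbonyl carbon.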